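Urea to benzamide on a shared pyrazole scaffold

The compounds below may be only part of what the source reports. "The series", "measured", "known", "first", "only" and "open" are said of these compounds alone.

Compound 2 `COc1cc(-c2nn(-c3cccc(NC(=O)Nc4cccc(C(F)(F)F)c4)c3)cc2-c2ccncc2)ccc1Cl` gives the lowest of the two numbers in a functional assay on CCRF-CEM cells (Homo sapiens) for inhibition, read by sulforhodamine B assay, with a stated time of 48 h (a higher number here means a weaker inhibitor of growth, a lower number a stronger inhibitor of growth), at 945 nM. For the measured compounds named here, its neighbour compound 1 `O=C(Nc1cccc(-n2cc(-c3ccncc3)c(-c3ccc(Cl)c(O)c3)n2)c1)Nc1cccc(C(F)(F)F)c1` gives 1400 nM in this assay, and the single measured step, a 1.5-fold lower number from compound 1 to compound 2 (0.17 log units; within the scatter), lies within the scatter. Compound 3 `COc1cc(-c2nn(-c3cccc(NC(=O)c4ccccc4)c3)cc2-c2ccncc2)ccc1Cl` differs from compound 2 by phenyl in place of (3-(trifluoromethyl)phenyl)amino on a carbonyl carbon. Going by the values given here, no measured step touches this part of the molecule, so the step from compound 1 to compound 2 offers no direct guide. In the absence of such data, a modest rise in the number is expected for compound 3, estimated at 3000 nM with a range of 800 nM to 12000 nM in this assay. This corresponds to an expected step of a 3.2-fold higher number from compound 2 to compound 3 (0.50 log units; beyond the scatter).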

Compound 3, concentration for 50% growth inhibition: 492 nM
Estimate against measurement, compound 3: 6.1-fold (0.79 log units) above, and the stated range ends above it.
By their numbers in this assay, from the lowest: compounds 3, 2 and 1 (each within the scatter of the next, the first and the last beyond it).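

In this assay, this is the first change shown at the carbonyl carbon, and it gives a step (a 1.9-fold lower number from compound 2 to compound 3 (0.28 log units; within the scatter)). The carbonyl carbon therefore accepts phenyl in place of (3-(trifluoromethyl)phenyl)amino without a step beyond the scatter, even though the entering group has fewer heavy atoms and no hydrogen-bond donor. No evidence available here accounts for this result.

Going by these compounds, whether an amine or a carboxylic acid on the entering phenyl would give a step beyond the scatter remains open. So does the outcome of the same change on compound 1, which keeps the hydrogen on the oxygen.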